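The source may hold more compounds than are shown below. What is called first, only, known or untested is meant among the compounds shown, and "the series" means these compounds.

Compound 1 `Nc1ccccc1NC(=O)c1ccc(CNc2nc(Cl)nc3c2ncn3Cc2ccccc2)cc1`, compound 2 `CCC(C)n1cnc2c(NCc3ccc(C(=O)Nc4ccccc4N)cc3)nc(Cl)nc21` and compound 3 `CCCCn1cnc2c(NCc3ccc(C(=O)Nc4ccccc4N)cc3)nc(Cl)nc21` share one core and differ only in the group carried on an aromatic nitrogen of that core. In a functional assay on HCT-116 cells (Homo sapiens) for antiproliferative activity, read by CCK-8 assay, with a stated time of 72 h, tested at 8 uM (on this read-out higher numbers stand for a stronger effect at the one concentration tested and lower numbers for a weaker effect), compound 1 gives 11.5%, compound 2 gives 75.1% and compound 3 gives 40.9%, so compound 3 stands second highest of the three, a number 29.4 percentage points higher from compound 1 to compound 3 (beyond the scatter) and a number 34.2 percentage points lower from compound 2 to compound 3 (beyond the scatter).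

Compound 4 `CCCn1cnc2c(NCc3ccc(C(=O)Nc4ccccc4N)cc3)nc(Cl)nc21` is not yet measured. It differs from compound 3 by hydrogen in place of methyl on a saturated chain carbon, three bonds along the chain from an aromatic nitrogen. Going by the values given here, no measured step shortens a chain in just this way. The nearest guides are the step that swaps sec-butyl for butyl, a number 34.2 percentage points lower from compound 2 to compound 3 (beyond the scatter), and the step that swaps phenyl for propyl, a number 29.4 percentage points higher from compound 1 to compound 3 (beyond the scatter). Both show that a small change on this chain can move the number well beyond the scatter, in either direction, so a sizeable step is possible here too, but its direction cannot be read from these three compounds. On that basis compound 4 is estimated at 45%, somewhere between 20% and 75%, which means an expected step of a number 4.1 percentage points higher from compound 3 to compound 4 (within the scatter).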

Compound 4, a percentage reported as inhibition, at one concentration (the size of the read-out at that concentration, not a potency): 29.6%
The estimate for compound 4 lay 15.4 percentage points above the measured number; the range from low to high includes it.
By their numbers in this assay, from the lowest: compound 1; then compound 4; then compound 3; then compound 2.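

In this assay, shortening the straight chain from butyl to propyl, a loss of one methyl, gives a number 11.3 percentage points lower from compound 3 to compound 4 (beyond the scatter), so this position responds to a single carbon of chain length and, for this pair, the shorter chain gives the lower number. The propyl compound still stands clearly apart from the other two groups, with a number 45.5 percentage points lower from compound 2 to compound 4 (beyond the scatter) and a number 18.1 percentage points higher from compound 1 to compound 4 (beyond the scatter), which leaves the four groups on this aromatic nitrogen all separated beyond the scatter. No measurement shown here explains these steps.

Going by these compounds alone, two straight chains make only one comparison, so a longer chain such as pentyl or a shorter one such as ethyl could either extend this direction or break it. From the compounds shown here alone, whether another branched group, such as isopropyl, would also reach the level of the sec-butyl compound remains open.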